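Amino alcohol chain replaces methylamino propyl on shared core

The source may report more compounds than this note shows. Statements on the series, on what has been measured and on what is new or still open speak of the compounds shown alone.

Compound 1 `CCCCCCCCCCc1ccc(-c2noc(CCCNC)n2)cc1`: 45%
Compound 2 `CCCCCCCCCCc1ccc(-c2noc([C@@H]3CCNC3)n2)cc1`: 62%

In an assay on HeLa cells for inhibition of sphingosine-1-phosphate transporter SPNS2 (Mus musculus), read by LC-MS, tested at 2 uM (on this read-out higher numbers stand for more inhibition at the one concentration tested (going by the name of the read-out) and lower numbers for less inhibition), compound 1 gives the lower of the two numbers; compound 2 sits a number 17 percentage points higher from compound 1 to compound 2 (beyond the scatter). Compound 3 `CCCCCCCCCCc1ccc(-c2noc(CC(O)CN)n2)cc1` is not yet measured. Against compound 1 the change is 2-amino-1-hydroxyethyl in place of 2-(methylamino)ethyl on a saturated chain carbon bound to an aromatic carbon. Among the measured compounds shown here, no measured step covers this change: the step from compound 1 to compound 2 alters a different part of the chain and gives no guide here, so no shift beyond the scatter is expected in this assay. Compound 3 is therefore estimated at 48%, between 30% and 66%, an expected a number 3 percentage points higher from compound 1 to compound 3 (within the scatter).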

Compound 3, a percentage reported as inhibition, at one concentration (the size of the read-out at that concentration, not a potency): 59%
The estimate for compound 3 lay 11 percentage points below the measured number; the measured number falls inside the stated range.
By their numbers in this assay, from the lowest: compound 1; then compounds 3 and 2 (each within the scatter of the next).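

In this assay, replacing 2-(methylamino)ethyl with 2-amino-1-hydroxyethyl on the saturated chain carbon bound to an aromatic carbon gives a number 14 percentage points higher from compound 1 to compound 3 (beyond the scatter), so an open-chain group can also shift the number, not only the pyrrolidin-3-yl ring. Set against that ring, 3-amino-2-hydroxypropyl gives a number 3 percentage points lower from compound 2 to compound 3 (within the scatter), so the two groups cannot be told apart here. Nothing given here accounts for either step. As far as these compounds go, whether the hydroxyl or the change of amine carries the step from compound 1 stays open, as does the effect of a carboxylic acid in place of the amine.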